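This account rests on a few compounds, and the source may have more. Where it says the series, first, only, none or still open, it means among the compounds named here.

Measured so far, in a functional assay on SGC-7901 cells (Homo sapiens) for antiproliferative activity, read by MTT assay, with a stated time of 72 h; a lower number here means a stronger inhibitor, a higher number a weaker inhibitor:
compound 1 `COc1ccc(-c2sc(C(=O)O)cc2-c2cc(OC)c(OC)c(OC)c2)cc1O` gives 6100 nM;
compound 2 `COc1ccc(-c2sccc2-c2cc(OC)c(OC)c(OC)c2)cc1O` gives 580 nM;
compound 3 `COc1ccc(-c2cc(C(=O)O)sc2-c2cc(OC)c(OC)c(OC)c2)cc1` gives 4220 nM.

Compound 4 `COc1ccc(-c2ccsc2-c2cc(OC)c(OC)c(OC)c2)cc1` is not yet measured.

The step of an 11-fold lower number from compound 1 to compound 2 (1.02 log units; beyond the scatter) came from the change (hydrogen in place of carboxy on an aromatic carbon). The same kind of change, (hydrogen in place of carboxy on an aromatic carbon), turns compound 3 into compound 4; the two place descriptions differ only in the group on the ring atom two ring bonds away, a 3-hydroxy-4-methoxyphenyl group in compound 1 against a 4-methoxyphenyl group in compound 3. The difference between the two cores is not broken down here. Compound 3 and compound 1 lie within the scatter of each other. Because the earlier step of an 11-fold lower number from compound 1 to compound 2 (1.02 log units; beyond the scatter) was large, a step of similar size is expected for compound 4, an 8.4-fold lower number from compound 3 to compound 4 (0.93 log units; beyond the scatter), with added uncertainty on the altered core. Compound 4 is estimated at 500 nM, within a range of 150 nM to 1600 nM.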

Compound 4, half-maximal inhibitory concentration: 2740 nM
Beside the measured number, compound 4's estimate is 5.5-fold (0.74 log units) below it; the measured number lies above the stated range.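

In this assay, hydrogen in place of carboxy gives a 1.5-fold lower number from compound 3 to compound 4 (0.19 log units; within the scatter), so on this core the change produces no step beyond the scatter. The size of the change therefore does not carry over unchanged between the two cores: the same change on two cores in this assay, an 11-fold lower number (1.02 log units; beyond the scatter) from compound 1 to compound 2 and a 1.5-fold lower number (0.19 log units; within the scatter) from compound 3 to compound 4, 6.8-fold (0.83 log units) apart, beyond the scatter of two such steps

Going by these compounds alone, with only one pair on each core, this does not show which difference between the cores accounts for the gap, nor how the change would behave on any further core. Still open, from the compounds shown here alone, is how a methyl ester or a primary amide in place of the carboxy would compare on each core. Also open, going by these compounds, is whether an amine on the phenyl ring of the core of compound 1 would give a step of either size.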